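A few compounds are considered here, and "the series" means these few. Any claim that something is new, unique, unknown or untested is made for them only; others in the source may bear on it.

Three compounds have been measured in a functional assay on NCI-H1975 cells (Homo sapiens) for cytotoxicity, read by MTT assay, with a stated time of 72 h; a higher number here means a weaker inhibitor, a lower number a stronger inhibitor:

Compound 1, `O=C(N/N=C/c1ccc(F)cc1)N1CCc2ncnc(Nc3ccc(F)c(Cl)c3)c2C1`, gives 64500 nM in this assay.
Compound 2, `O=C(N/N=C/c1cccs1)N1CCc2ncnc(Nc3ccc(F)c(Cl)c3)c2C1`, gives 33000 nM in this assay.
Compound 3, `O=C(N/N=C/c1ccc(F)cc1)N1CCc2ncnc(Nc3cccc(Br)c3)c2C1`, gives 37600 nM in this assay.

Compound 2 is compound 1 with one group exchanged: thiophen-2-yl in place of 4-fluorophenyl on a carbon with a double bond to nitrogen. That exchange made a step of a 2.0-fold lower number from compound 1 to compound 2 (0.29 log units; within the scatter), so the two numbers are not separated by more than the usual scatter.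

Compound 3 carries the same group as compound 1 on the carbon with a double bond to nitrogen, but its core differs: 3-bromophenyl in place of 3-chloro-4-fluorophenyl on a nitrogen on an aromatic ring. The step of this core change is a 1.7-fold lower number from compound 1 to compound 3 (0.23 log units; within the scatter), again within the scatter. Compounds 2 and 3 have not been compared as a pair in this way; their values lie close together.

Compound 4, `O=C(N/N=C/c1cccs1)N1CCc2ncnc(Nc3cccc(Br)c3)c2C1`, has not yet been measured in this assay. It stands to compound 3 as compound 2 stands to compound 1: thiophen-2-yl in place of 4-fluorophenyl on a carbon with a double bond to nitrogen. The place of the change reads the same word for word in both pairs, so it is the same change on a different core.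

Within the data shown here, on the single measured instance of this change, the step of a 2.0-fold lower number from compound 1 to compound 2 (0.29 log units; within the scatter), the expected step from compound 3 to compound 4 is a 1.9-fold lower number from compound 3 to compound 4 (0.27 log units; within the scatter). Because compound 3 gives 37600 nM, compound 4 is estimated at 20000 nM in this assay, with a likely range from 8000 nM to 45000 nM.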

Compound 4, half-maximal inhibitory concentration: 122000 nM
Estimate against measurement, compound 4: 6.1-fold (0.79 log units) below; measured number above the stated range.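

In this assay, the exchange of 4-fluorophenyl for thiophen-2-yl did not carry from one core to the other: on the core of compound 3 it gave a 3.2-fold higher number from compound 3 to compound 4 (0.51 log units; beyond the scatter), and this step differs from the one on the core of compound 1: the same change on two cores in this assay, a 2.0-fold lower number (0.29 log units; within the scatter) from compound 1 to compound 2 and a 3.2-fold higher number (0.51 log units; beyond the scatter) from compound 3 to compound 4, 6.3-fold (0.80 log units) apart, beyond the scatter of two such steps. Read the other way, the exchange of 3-chloro-4-fluorophenyl for 3-bromophenyl on a nitrogen on an aromatic ring gave a 3.7-fold higher number from compound 2 to compound 4 (0.57 log units; beyond the scatter) when thiophen-2-yl was present, and this too differs from the step seen with 4-fluorophenyl: the same change on two cores in this assay, a 1.7-fold lower number (0.23 log units; within the scatter) from compound 1 to compound 3 and a 3.7-fold higher number (0.57 log units; beyond the scatter) from compound 2 to compound 4, 6.3-fold (0.80 log units) apart, beyond the scatter of two such steps. These four compounds therefore show that the two changes do not add up simply here and that the outcome of each depends on the group at the other place, but they do not show why, and a single such set cannot establish how far this holds across the series.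

As far as these compounds go, it remains open whether a furan-2-yl or a pyridin-2-yl on the carbon with a double bond to nitrogen would follow the 4-fluorophenyl or the thiophen-2-yl pattern on these two cores. From the compounds shown here alone, it is equally open whether a 3-chlorophenyl or a 3-ethynylphenyl on the nitrogen would show the same dependence.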